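Swapping the Aryl Group: Cytotoxicity Estimate for Compound 4

The source may hold more compounds than are shown below. What is called first, only, known or untested is meant among the compounds shown, and "the series" means these compounds.

Measured so far in an ADME assay on Huh7.5.1 cells (Homo sapiens) for cytotoxicity, read by ATP content, with a stated time of 48 h; on this read-out higher numbers stand for lower toxicity in this test and lower numbers for higher toxicity in this test:
compound 1 `Cc1oc(-c2ccc(Cl)c(Cl)c2)nc1CN1CCC(C(=O)NCCCN2C[C@H](C)C[C@H](C)C2)CC1` gives 3170 nM;
compound 2 `Cc1oc(-c2c(Br)cccc2Br)nc1CN1CCC(C(=O)NCCCN2C[C@H](C)C[C@H](C)C2)CC1` gives 6500 nM;
compound 3 `Cc1oc(-c2c(Cl)cccc2C(F)(F)F)nc1CN1CCC(C(=O)NCCCN2C[C@H](C)C[C@H](C)C2)CC1` gives 12000 nM.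

Compound 3 has the highest number of the three in this assay; the gap to compound 2 is within the scatter, while the step of a 3.8-fold higher number from compound 1 to compound 3 (0.58 log units; beyond the scatter) is beyond it.

Compound 4 `Cc1ccc(-c2nc(CN3CCC(C(=O)NCCCN4C[C@H](C)C[C@H](C)C4)CC3)c(C)o2)cc1C` differs from compound 3 by 3,4-dimethylphenyl in place of 2-chloro-6-(trifluoromethyl)phenyl on an aromatic carbon. Going by the values given here, the steps that bear on this change are a 2.1-fold higher number from compound 1 to compound 2 (0.31 log units; beyond the scatter) and a 3.8-fold higher number from compound 1 to compound 3 (0.58 log units; beyond the scatter), both swaps at the same aromatic carbon. Compound 4 carries a 3,4-substitution pattern like compound 1 rather than the 2,6-pattern of compound 3, so a modestly lower number is expected: a 2.4-fold lower number from compound 3 to compound 4 (0.38 log units; beyond the scatter). Compound 4 is therefore estimated at 5000 nM, within 2000 nM to 12000 nM.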

Compound 4, half-maximal cytotoxic concentration: 6910 nM
Estimate against measurement, compound 4: 1.4-fold (0.14 log units) below; the measured number falls inside the stated range.
By their numbers in this assay, from the lowest: compound 1; then compounds 2, 4 and 3 (each within the scatter of the next).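

In this assay, the step of a 2.2-fold higher number from compound 1 to compound 4 (0.34 log units; beyond the scatter) shows that, with the 3,4-pattern kept, changing the ring's two chlorines to methyl groups moves the number beyond the scatter. The steps of a 1.7-fold lower number from compound 3 to compound 4 (0.24 log units; within the scatter) and a 1.1-fold higher number from compound 2 to compound 4 (0.03 log units; within the scatter) both lie within the scatter, so at this position a 3,4-substituted ring can match the 2,6-substituted rings of compound 2 and compound 3. No measurement shown explains these differences. Still open, as far as these compounds go, is how 2,6-dimethylphenyl would compare with 3,4-dimethylphenyl in this assay on the same core. Also open, from the compounds shown here alone, is how a plain phenyl ring, or a phenyl ring bearing an amine or a carboxylic acid, would read there.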